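One Methyl Less on the Side Chain of Compound 2

The compounds below may be only part of what the source reports. "The series", "measured", "known", "first", "only" and "open" are said of these compounds alone.

Of the compounds shown here, three sharing one core have been measured in a functional assay on K562 cells (Homo sapiens) for cytotoxicity, read by MTT assay, with a stated time of 72 h; on this read-out higher numbers stand for weaker inhibition and lower numbers for stronger inhibition. Compound 1 `CCCOCNc1n[n+]([O-])c2cc(OC)ccc2[n+]1[O-]` gives 4280 nM. Compound 2 `COc1ccc2c(c1)[n+]([O-])nc(NCOC(C)c1ccccc1)[n+]2[O-]` gives 6690 nM, and compound 3 `O=[N+]([O-])c1cccc(COCNc2n[n+]([O-])c3ccccc3[n+]2[O-])c1` gives 5650 nM. Compound 2 has the highest of the three numbers, but its gaps to the others lie within the usual scatter of repeated measurements, so the three cannot be ranked. For the measured compounds named here, the one direct comparison among them, a 1.6-fold higher number from compound 1 to compound 2 (0.19 log units; within the scatter), shows that swapping propyl for 1-phenylethyl on an oxygen on a saturated carbon changed little.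

Compound 4 `COc1ccc2c(c1)[n+]([O-])nc(NCOCc1ccccc1)[n+]2[O-]` is not yet measured. It differs from compound 2 in one place: hydrogen in place of methyl on a saturated chain carbon bound to an aromatic carbon and an oxygen on a saturated carbon. The same difference, cut one bond further out, reads 1-phenylethyl to benzyl.

Going by the values given here, no measured step removes exactly this methyl. The nearest guide is that compound 1, compound 2 and compound 3 all lie within the scatter of one another, so changes at this end of the side chain have so far barely moved this assay. The step expected is a 1.2-fold lower number from compound 2 to compound 4 (0.09 log units; within the scatter), no larger than the scatter. The estimate for compound 4 is 5500 nM, with a range from 2500 nM to 12000 nM.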

Compound 4, half-maximal inhibitory concentration: 27500 nM
For compound 4 the middle estimate is 5.0-fold (0.70 log units) below the measured one; measured number outside the range, above it.
By their numbers in this assay, from the lowest: compounds 1, 3 and 2 (each within the scatter of the next); then compound 4.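

In this assay, the methyl on the saturated chain carbon bound to an aromatic carbon and an oxygen on a saturated carbon proves to matter: taking it away, so that 1-phenylethyl becomes benzyl, gives a 4.1-fold higher number from compound 2 to compound 4 (0.61 log units; beyond the scatter), a step beyond the scatter, whereas a 1.6-fold higher number from compound 1 to compound 2 (0.19 log units; within the scatter) had suggested that this end of the side chain barely affected the read-out. For the compounds shown here, the phenyl ring alone does not set the number, since compound 2 and compound 4 both carry it, yet only the step to compound 4 that puts phenyl in place of ethyl, a 6.4-fold higher number from compound 1 to compound 4 (0.81 log units; beyond the scatter), lies beyond the scatter, while the step to compound 2 does not. Nothing available here explains why removing this one methyl shifts the number so clearly.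

As far as these compounds go, it remains open whether an ethyl group or a hydroxyl group on that same chain carbon would keep the number near that of compound 2 or shift it as hydrogen does. Also open, from the compounds shown here alone, is whether a fluorine or a methoxy group on the phenyl ring of compound 4 would change its number.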